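A few compounds are considered here, and "the series" means these few. Any claim that something is new, unique, unknown or untested is made for them only; others in the source may bear on it.

Measured so far:
compound 1 `CC(=O)Oc1ccccc1C(=O)O[C@H]1CO[C@H]2[C@@H]1OC[C@H]2OC(=O)c1snnc1C` — 0.0065 h
compound 2 `CC(=O)Oc1ccccc1C(=O)O[C@H]1CO[C@H]2[C@@H]1OC[C@H]2OC(=O)c1ccc([N+](=O)[O-])cc1` — 0.0227 h

In an ADME assay on a cell-free system (plasma, Homo sapiens) for metabolic stability, with Plasma (Rattus norvegicus) as the target, read by HPLC, at pH 7.4 (a lower number here means that the compound disappears faster, a higher number that the compound lasts longer), compound 2 gives 0.0227 h, the higher of the two numbers; compound 1 gives 0.0065 h, and the step of a 3.5-fold higher number from compound 1 to compound 2 (0.54 log units; beyond the scatter) is the only one recorded in this series. Compound 3 `CC(=O)Oc1ccccc1C(=O)O[C@H]1CO[C@H]2[C@@H]1OC[C@H]2OC(=O)c1cccc(CO[N+](=O)[O-])c1` differs from compound 2 by 3-((nitrooxy)methyl)phenyl in place of 4-nitrophenyl on a carbonyl carbon. For the measured compounds named here, no measured pair isolates this change: the one step that bears on it exchanged the whole ring on the carbonyl carbon, and its size, a 3.5-fold higher number from compound 1 to compound 2 (0.54 log units; beyond the scatter), merely shows that such exchanges shift this assay modestly. Compound 3 keeps the six-membered aromatic carbon ring of compound 2, so no larger shift is expected; the direction is open, so the estimated step of a 1.1-fold lower number from compound 2 to compound 3 (0.05 log units; within the scatter) is expected to stay within the scatter. For compound 3 the expected value in this assay is 0.02 h, with a range from 0.007 h to 0.06 h.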

Compound 3, half-life: 0.045 h
Beside the measured number, compound 3's estimate is 2.3-fold (0.35 log units) below it; low and high end bracket the measured number.
By their numbers in this assay, from the lowest: compound 1; then compounds 2 and 3 (each within the scatter of the next).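

In this assay, the larger 3-((nitrooxy)methyl)phenyl on the carbonyl carbon cannot be told apart from 4-nitrophenyl, with a 2.0-fold higher number from compound 2 to compound 3 (0.30 log units; within the scatter). Compound 3 also stands clear of the thiadiazole compound, with a 6.9-fold higher number from compound 1 to compound 3 (0.84 log units; beyond the scatter), so among these three compounds, the two that carry a six-membered aromatic ring of carbon only both lie beyond the scatter of compound 1, and the nitrooxymethyl-bearing ring gives up nothing measurable relative to the nitro-bearing one. Nothing available explains why the thiadiazole ester stands apart or what the nitrooxymethyl group contributes.

From the compounds shown here alone, whether this level holds for plain phenyl, or for a phenyl ring carrying an amine or a carboxylic acid, remains open. Going by these compounds, with only these compounds, it also remains open whether a longer chain ending in nitrooxy would keep compound 3's reading.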